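The compounds below may be only part of what the source reports. "The series", "measured", "known", "first", "only" and "open" are said of these compounds alone.

Measured so far in a functional assay on ZR-75-1 cells (Homo sapiens) for cytotoxicity; a lower number here means that less compound is needed, a higher number that more compound is needed for the effect:

- compound 2 `C=C1C(=O)O[C@@H]2[C@@H]1CC[C@H](C)[C@@](O)(C(=O)/C=C/C)[C@H]2OC(=O)/C(C)=C\C`: 1.4 ug/mL
- compound 3 `C=C1C(=O)O[C@@H]2[C@@H]1C[C@@H](O)[C@H](C)[C@@](O)(C(=O)/C=C/C)[C@H]2OC(=O)/C(C)=C\C`: 0.2 ug/mL
- compound 1 `C=C[C@@](C)(O)C[C@@H](O)/C=C(\C)CC/C=C(\C)COC(C)=O`: "not determined" (no result reported)

Compound 2 stands at the highest of the two numbers obtained in this assay; the nearest entry is compound 3, reached by a 7.0-fold lower number from compound 2 to compound 3 (0.85 log units; beyond the scatter). For compound 1 no number exists, so it gives no guidance on the series.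

The next compound, compound 4 `C=C1C(=O)O[C@@H]2[C@@H]1[C@@H](O)C[C@H](C)[C@@](O)(C(=O)/C=C/C)[C@H]2OC(=O)/C(C)=C\C`, is also built from compound 2 by a single change: hydroxy in place of hydrogen on a saturated ring carbon. Within the data shown here, the only measured step that bears on this change is the one from compound 2 to compound 3, where a hydroxy also replaced a hydrogen on a saturated ring carbon of the same core, though at a different ring position; that step was beyond the scatter and brought a lower number. On that basis a step in the same direction is expected for compound 4, though the different place of the hydroxy leaves its size uncertain, and a smaller shift than seen for compound 3 cannot be excluded.

Compound 4 is therefore estimated at 0.5 ug/mL in this assay, within 0.15 ug/mL to 1.6 ug/mL, corresponding to an expected step of a 2.8-fold lower number from compound 2 to compound 4 (0.45 log units; beyond the scatter).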

Compound 4, concentration for half-maximal effect: 1.4 ug/mL
Compound 4: middle estimate off by 2.8-fold (0.45 log units), on the low side, and the stated range covers the measured number.
By their numbers in this assay, from the lowest: compound 3; then compounds 2 and 4 (each within the scatter of the next).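

In this assay, hydroxy in place of hydrogen on the saturated ring carbon of the seven-membered ring, next to the ring atom that bears a fused ring, gives no change at the digits printed from compound 2 to compound 4 (within the scatter), so this position tolerates the added hydroxy without a readable shift in the number. The same kind of replacement at a different ring carbon gave a 7.0-fold lower number from compound 2 to compound 3 (0.85 log units; beyond the scatter), which lies beyond the scatter, so across these two compounds the outcome depends on where the hydroxy stands and not on its presence on the core alone. No measurement available here accounts for the difference between the two positions.

The compounds shown leave open whether an amine, a methoxy group or an acetate ester at this carbon would also stay within the scatter of compound 2, or would move the number as the hydroxy of compound 3 did at its own position. Also open, from the compounds shown here alone, is whether the opposite spatial arrangement of the hydroxy at this carbon would read the same in this assay.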